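Notes on chain-amine variation around a shared core

This account rests on a few compounds, and the source may have more. Where it says the series, first, only, none or still open, it means among the compounds named here.

Measured so far:
compound 1 `CCc1cc(CC)c2ccc(=O)n(CCN(C)C)c2n1`: 5.19 ug/mL
compound 2 `Cc1cc(C)c2ccc(=O)n(CCN)c2n1`: 33.8 ug/mL

In an assay on isolated protein (strain Charles River) for antagonist activity at histamine H2 receptor (Rattus norvegicus) (a higher number here means that more compound is needed for the effect, a lower number that less compound is needed), compound 1 gives 5.19 ug/mL and compound 2 gives 33.8 ug/mL. Compound 2 carries the higher of the two numbers, and its gap to compound 1 lies beyond the scatter. Within the data shown here, the two compounds differ in more than one place, the alkyls on the core as well as the chain amine, so no single step separates them; their values show only that compound 2 needs more material.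

Compound 3 `Cc1cc(C)c2ccc(=O)n(CC(C)(C)N(C)C)c2n1` is not yet measured. It keeps the core of compound 2 and alters the chain: 1-(dimethylamino)-1-methylethyl in place of aminomethyl on a saturated chain carbon bound to an aromatic nitrogen. Among the measured compounds shown here, no measured pair isolates this change, so the expectation rests on the two values at hand. A step toward a lower number is expected for a 2.8-fold lower number from compound 2 to compound 3 (0.45 log units; beyond the scatter), because compound 1 with its dimethylated chain amine gives 5.19 ug/mL in this assay. The expected size is moderate and uncertain, since the core also differs between compound 1 and compound 2. Compound 3 is estimated at 12 ug/mL, with a range from 4 ug/mL to 35 ug/mL.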

Compound 3, half-maximal effective concentration: 10.4 ug/mL
Estimate against measurement, compound 3: 1.2-fold (0.06 log units) above; the range from low to high includes it.
By their numbers in this assay, from the lowest: compounds 1 and 3 (each within the scatter of the next); then compound 2.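

In this assay the series now has its first comparison that differs in one place only: with the core held, 1-(dimethylamino)-1-methylethyl in place of aminomethyl on a saturated chain carbon bound to an aromatic nitrogen gives a 3.3-fold lower number from compound 2 to compound 3 (0.51 log units; beyond the scatter), a modest step. This position therefore accepts a group of 6 heavy atoms with 0 hydrogen-bond donors in place of one of 2 heavy atoms with 1 hydrogen-bond donor, and the number does not rise. The change alters the amine and the chain carbon together, and nothing on hand gives a reason for the step.

Still open, on these data alone, is how much of the step belongs to the dimethylamino group and how much to the added methyl groups on the chain; on the core of compound 2, a dimethylaminomethyl group or a 1-amino-1-methylethyl group would separate the two. Also open, as far as these compounds go, is how the number responds to a ring amine such as pyrrolidine, a longer chain, or a carboxylic acid in this place.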